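A Fluorophenyl Analogue of the Strongest Glucosidase Inhibitor

The source may hold more compounds than are shown below. What is called first, only, known or untested is meant among the compounds shown, and "the series" means these compounds.

Three iminosugar ethers have been measured in an assay on isolated protein for inhibition of Beta-glucosidase (Homo sapiens); a lower number here means a stronger inhibitor, a higher number a weaker inhibitor. Compound 1 `COc1ccc(-c2ccc(COCCCCCN3C[C@H](O)[C@@H](O)[C@H](O)[C@H]3CO)cc2)cc1` gives 10 nM. Compound 2 `COc1cccc(-c2ccc(COCCCCCN3C[C@H](O)[C@@H](O)[C@H](O)[C@H]3CO)cc2)c1` gives 20 nM. Compound 3 `N#Cc1ccc(-c2ccc(COCCCCCN3C[C@H](O)[C@@H](O)[C@H](O)[C@H]3CO)cc2)cc1` gives 3 nM, the lowest number of the three, and its steps to both other compounds lie beyond the scatter, so compound 3 is the strongest inhibitor here. Compound 4 `OC[C@@H]1[C@@H](O)[C@H](O)[C@@H](O)CN1CCCCCOCc1ccc(-c2ccccc2F)cc1` differs from compound 3 in one place: 2-fluorophenyl in place of 4-cyanophenyl on an aromatic carbon. Among the compounds with values here, two measured steps bear on this change. The step of a 3.3-fold lower number from compound 1 to compound 3 (0.52 log units; beyond the scatter) and the step of a 6.7-fold lower number from compound 2 to compound 3 (0.82 log units; beyond the scatter) both show that the ring carrying the cyano group gave the lowest number of the set. With that group gone, a higher number is expected, and compound 4 is estimated at 15 nM, between 5 nM and 45 nM, which is expected to mean a 5.0-fold higher number from compound 3 to compound 4 (0.70 log units; beyond the scatter).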

Compound 4, half-maximal inhibitory concentration: 2 nM
Estimate against measurement, compound 4: 7.5-fold (0.88 log units) above, outside the stated range (below it).
By their numbers in this assay, from the lowest: compounds 4 and 3 (each within the scatter of the next); then compounds 1 and 2 (each within the scatter of the next).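

In this assay, the nitrile proves unnecessary for a low number at this place: 2-fluorophenyl in place of 4-cyanophenyl gives a 1.5-fold lower number from compound 3 to compound 4 (0.18 log units; within the scatter). The fluorinated ring also separates from both methoxyphenyl rings, with a 10-fold lower number from compound 2 to compound 4 (1.00 log units; beyond the scatter) and a 5.0-fold lower number from compound 1 to compound 4 (0.70 log units; beyond the scatter). No measurement offered here accounts for this result.

From the compounds shown here alone, it remains open whether the fluorine contributes at all, and whether plain phenyl, or a ring carrying an amine or a carboxylic acid, would hold this level.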